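Compound 4 and a read-out resting at its limit

This account rests on a few compounds, and the source may have more. Where it says the series, first, only, none or still open, it means among the compounds named here.

In an ADME assay on BJ cells (Homo sapiens) for cytotoxicity, with a stated time of 72 h (on this read-out lower numbers stand for an effect already at smaller amounts and higher numbers for an effect only at larger amounts of compound), compound 1 `C=C[C@@](C)(/C=C/c1ccc(OCc2ccccc2)cc1)CCC=C(C)C` gives > 36600 nM as a limit and not a number. Compound 2 `C=C[C@@](C)(/C=C/c1ccc(Nc2ccc(OC)cc2)cc1)CCC=C(C)C` gives > 36600 nM as a limit too. Compound 3 `C=C[C@@](C)(/C=C/c1ccc(Nc2cc(F)cc(F)c2)cc1)CCC=C(C)C` likewise gives > 36600 nM as a limit, so it offers no number to start from. Going by the values given here, compound 4 `C=C[C@@](C)(/C=C/c1ccc(Nc2ccc(Cl)c(F)c2)cc1)CCC=C(C)C` has 4-chloro-3-fluorophenyl in place of 3,5-difluorophenyl on a nitrogen on an aromatic ring as its one change. The measured steps a step that the two limits leave unreadable from compound 1 to compound 2 and a step that the two limits leave unreadable from compound 1 to compound 3 show no size. With a step that the two limits leave unreadable from compound 2 to compound 3 as the nearest guide, no step beyond the usual scatter is expected, and the estimated step reads a number no higher from compound 3 to compound 4 (the limit leaves the size open) here. Compound 4 is expected at 36600 nM with an estimated range from 15000 nM to 60000 nM as its likely span.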

Compound 4, half-maximal effective concentration: > 36600 nM
Compound 4 ended at the assay's limit (the forecaster's own chance of this, stated with the estimate: 80%); the middle value sits exactly at the limit.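

The steps from compounds 1, 2 and 3 to compound 4 cannot be read, since all four values are limits and not numbers: the limit of > 36600 nM in this assay, at which 4 of the 4 values shown sit.

Going by these compounds, what amount of any of these four compounds would produce the effect in this assay stays open.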